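The compounds below may be only part of what the source reports. "The series", "measured", "known", "first", "only" and "open" are said of these compounds alone.

Compound 3 `Cc1c(C(=O)Nc2c(F)cc(-c3cccc(F)c3)cc2F)nc2ccc(F)cc2c1C(=O)O` gives 34.3% in a functional assay on Hep 3B2 cells (Homo sapiens) for antiproliferative activity, read by MTT assay, with a stated time of 24 h, tested at 33.33 ug/mL (on this read-out lower numbers stand for a weaker effect and higher numbers for a stronger effect at the one concentration tested), the second highest of the three numbers measured; compound 2 `CCc1ccc2nc(C(=O)Nc3c(F)cc(-c4cccc(F)c4)cc3F)c(C)c(C(=O)O)c2c1` gives 36.3%, within the scatter of compound 3, while compound 1 `CCOc1ccc2nc(C(=O)Nc3c(F)cc(-c4cccc(F)c4)cc3F)c(C)c(O)c2c1` gives 11.2%, well below it. Compound 4 `CCOc1ccc2nc(C(=O)Nc3c(F)cc(-c4cccc(F)c4)cc3F)c(C)c(C(=O)O)c2c1` differs from compound 3 in one place: ethoxy in place of fluoro on an aromatic carbon. Within the data shown here, the one measured step at this same place, a number 2 percentage points lower from compound 2 to compound 3 (within the scatter), lay within the scatter, so a small group there changed little. Compound 1 also carries an ethoxy group but differs from compound 4 elsewhere, so its low number gives no direct guide. The expected step is therefore small, a number 1.3 percentage points lower from compound 3 to compound 4 (within the scatter). Compound 4 is estimated at 33%, with a range from 20% to 46%.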

Compound 4, a percentage reported as inhibition, at one concentration (the size of the read-out at that concentration, not a potency): 38.7%
Estimate against measurement, compound 4: 5.7 percentage points below; low and high end bracket the measured number.
By their numbers in this assay, from the lowest: compound 1; then compounds 3, 2 and 4 (each within the scatter of the next).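

At this position on the shared core, ethoxy in place of fluoro gives a number 4.4 percentage points higher from compound 3 to compound 4 (within the scatter), and ethoxy in place of ethyl gives a number 2.4 percentage points higher from compound 2 to compound 4 (within the scatter), so fluoro, ethyl and ethoxy cannot be told apart in this assay. With ethoxy held fixed, carboxy in place of hydroxy at the other site gives a number 27.5 percentage points higher from compound 1 to compound 4 (beyond the scatter), a change that, unlike those at the ethoxy position, lies beyond the scatter. Nothing available explains either result. On these data alone, whether an amine or a longer butoxy chain at the ethoxy position would also leave the number within the scatter remains open. So does whether a methyl ester could stand in for carboxy at the other site.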